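The source may report more compounds than this note shows. Statements on the series, on what has been measured and on what is new or still open speak of the compounds shown alone.

In a functional assay on PC-3 cells (Homo sapiens) for cytotoxicity, with a stated time of 48 h (on this read-out higher numbers stand for weaker inhibition and lower numbers for stronger inhibition), compound 1 `COc1cc(OC)c(C(=O)/C=C/c2ccccc2SC)c(OC)c1` gives 7600 nM, and compound 3 `COc1cc(OC)c(C(=O)/C=C/c2ccc(Cl)cc2)c(OC)c1` gives 5800 nM, a 1.3-fold lower number from compound 1 to compound 3 (0.12 log units; within the scatter), within the scatter. Compound 2 `COc1cccc(/C=C/C(=O)c2c(OC)cc(OC)cc2OC)c1` gives 3100 nM, a 2.5-fold lower number from compound 1 to compound 2 (0.39 log units; beyond the scatter), a modest step beyond the scatter. Compound 4 `COc1cc(O)c(C(=O)/C=C/c2ccccc2SC)c(OC)c1` differs from compound 1 by hydrogen in place of methyl on an oxygen on an aromatic ring, methoxy to hydroxy. Both measured steps change the group on the double-bonded chain carbon, and none touches this oxygen, so they give only a rough scale for the series. In this assay, the expected change is a 1.3-fold lower number from compound 1 to compound 4 (0.10 log units; within the scatter), with no step beyond the scatter anticipated. For compound 4 the estimate is 6000 nM, with an expected range of 2000 nM to 18000 nM.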

Compound 4, half-maximal inhibitory concentration: 8700 nM
Compound 4: middle estimate off by 1.5-fold (0.16 log units), on the low side; measured number inside the range.
By their numbers in this assay, from the lowest: compounds 2, 3, 1 and 4 (each within the scatter of the next, the first and the last beyond it).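

Hydrogen in place of methyl on an oxygen on an aromatic ring gives a 1.1-fold higher number from compound 1 to compound 4 (0.06 log units; within the scatter) in this assay, the first reading at this oxygen, which the earlier steps left untouched. The methyl on this oxygen can therefore go with no step beyond the scatter, at least with 2-(methylsulfanyl)phenyl on the chain. No measured evidence bears on why this change leaves the number within the scatter.

As far as these compounds go, whether the same change behaves alike with 3-methoxyphenyl or 4-chlorophenyl on the chain stays open. So does the outcome with a longer chain, such as ethyl, or an aminoethyl group on this oxygen.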